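Taking the Methyl Away: What to Expect for Compound 3

The compounds below may be only part of what the source reports. "The series", "measured", "known", "first", "only" and "open" are said of these compounds alone.

Measured so far:
- compound 1, `COC(=O)c1sc2cc(OC)ccc2c1Nc1cc(OC)c(OC)c(OC)c1`, gives 10.3 nM in a functional assay on SEM cells (Homo sapiens) for cytotoxicity, read by MTT assay, with a stated time of 72 h; on this read-out lower numbers stand for stronger inhibition and higher numbers for weaker inhibition.
- compound 2, `COC(=O)c1sc2cc(C)ccc2c1Nc1cc(OC)c(OC)c(OC)c1`, gives 0.7 nM in this assay.

For the measured compounds named here, compound 2 holds the lower of the two numbers; its nearest neighbour is compound 1, and the single measured step, a 15-fold lower number from compound 1 to compound 2 (1.17 log units; beyond the scatter), is a large one. Compound 3, `COC(=O)c1sc2ccccc2c1Nc1cc(OC)c(OC)c(OC)c1`, differs from compound 2 in one place: hydrogen in place of methyl on an aromatic carbon. Going by the values given here, no measured step removes a methyl outright, so that one step is only a hint: exchanging methoxy for methyl moved the number a great deal, and what hydrogen at the same place does is not known from these two compounds. Compound 3 is therefore expected to fall between the two measured numbers, with a wide range. The expected step is a 4.3-fold higher number from compound 2 to compound 3 (0.63 log units; beyond the scatter). For compound 3 the estimate is 3 nM, within 0.7 nM to 15 nM.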

Compound 3, half-maximal inhibitory concentration: 179 nM
Beside the measured number, compound 3's estimate is 60-fold (1.78 log units) below it; measured number above the stated range.
By their numbers in this assay, from the lowest: compound 2; then compound 1; then compound 3.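

In this assay the bare aromatic carbon turns out to be the poor case, not a midpoint between methoxy and methyl: hydrogen in place of methyl gives a 260-fold higher number from compound 2 to compound 3 (2.41 log units; beyond the scatter) on this read-out, and hydrogen in place of methoxy gives a 17-fold higher number from compound 1 to compound 3 (1.24 log units; beyond the scatter) as well. Both steps are large, so each of the two groups at this place goes with a much lower number than hydrogen does, and compound 3 has the highest number of the three. Why a group here matters so much cannot be told, as nothing measured on these compounds bears on it.

The compounds shown leave open whether a longer chain such as ethyl, a chlorine atom or an amine at this aromatic carbon would keep the number low. They also leave open whether methyl would have a similar effect on the other carbons of this six-membered ring.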